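Working notes: compound 2 to compound 3

This account rests on a few compounds, and the source may have more. Where it says the series, first, only, none or still open, it means among the compounds named here.

Measured so far:
compound 1, `CCCCCCCCCCCCCCCCOP(=O)(O)OCCSC(=S)N1CCCCC1`: 100000 nM
compound 2, `CCCOP(=O)(O)OCCSC(=S)N1CCCC1`: 67000 nM

Both numbers come from a functional assay on MDA-MB-231 cells (Homo sapiens) for inhibition, read by MTT assay, with stated times of 18 h and 4 h; a lower number here means a stronger inhibitor, a higher number a weaker inhibitor. In this assay compound 1 gives 100000 nM and compound 2 gives 67000 nM. Compound 2 holds the lower of the two numbers, but the gap to compound 1 lies within the scatter, so no order between the two can be read. Compound 1 and compound 2 also differ from each other in more than one place, so nothing is known about any single change between them.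

Compound 3, `CCCCCCOP(=O)(O)OCCSC(=S)N1CCCC1`, is not yet measured. The change from compound 2 is propyl in place of hydrogen on a saturated chain carbon, three bonds along the chain from an oxygen on an unsaturated carbon. For the measured compounds named here, no measured pair isolates a change of this kind, so there is no step on record to lean on. The two numbers in hand are both weak and sit within the scatter of each other, which gives no ground to expect compound 3 to move far from compound 2. In this assay compound 3 is expected at about 60000 nM, within 20000 nM to 180000 nM. The step that this estimate means is a 1.1-fold lower number from compound 2 to compound 3 (0.05 log units; within the scatter), which is expected to stay inside the scatter rather than mark a real change.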

Compound 3, half-maximal inhibitory concentration: 54000 nM
Beside the measured number, compound 3's estimate is 1.1-fold (0.05 log units) above it; the measured number falls inside the stated range.
By their numbers in this assay, from the lowest: compounds 3, 2 and 1 (each within the scatter of the next).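

In this assay, for the compounds shown here, propyl in place of hydrogen on a saturated chain carbon, three bonds along the chain from an oxygen on an unsaturated carbon, gives a 1.2-fold lower number from compound 2 to compound 3 (0.09 log units; within the scatter), the first step that isolates a single change. Read in the same terms as propyl to hexyl, this change leaves compound 2 and compound 3 indistinguishable in this assay, so at this position the added propyl brings neither a readable gain nor a readable loss. No measured property of these compounds bears on the result.

The pairs with compound 1 differ in more than one place and cannot be read as steps, so this single step is all that the compounds shown offer on this chain, and it says nothing about how a change elsewhere on the shared core would read. On these data alone, whether a longer chain, an amine or a carboxylic acid at this position would give a number beyond the scatter from compound 3 remains open.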